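The compounds below may be only part of what the source reports. "The series", "measured", "known", "first", "only" and "open" are said of these compounds alone.

Measured so far in a functional assay with Cavia porcellus as the target; on this read-out lower numbers stand for an effect already at smaller amounts and higher numbers for an effect only at larger amounts of compound:
- compound 1 `COC(=O)c1c(C)[nH]c(C)c1C(=O)c1ccccc1Cl`: 14000 nM
- compound 2 `COC(=O)c1c(C(=O)c2ccccc2Cc2ccccc2)c[nH]c1C`: 460 nM
- compound 3 `COC(=O)c1c(C)[nH]c(C)c1C(=O)c1ccccc1I`: 5900 nM

Compound 2 gives the lowest number of the three in this assay; compound 3 and compound 1 sit higher, each beyond the scatter. For the measured compounds named here, the only single-point step measured is the halogen swap a 2.4-fold lower number from compound 1 to compound 3 (0.38 log units; beyond the scatter), which does not touch the part of the core changed here.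

Compound 4 `COC(=O)c1c[nH]cc1C(=O)c1ccccc1Cc1ccccc1` differs from compound 2 by hydrogen in place of methyl on an aromatic carbon. Going by the values given here, no measured step bears on this change, so the expectation rests on compound 2 alone. Compound 4 is estimated to give 1000 nM (range 300 nM to 3500 nM), a modest step toward higher numbers, a 2.2-fold higher number from compound 2 to compound 4 (0.34 log units; beyond the scatter), expected but uncertain.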

Compound 4, half-maximal effective concentration: 2100 nM
Beside the measured number, compound 4's estimate is 2.1-fold (0.32 log units) below it, within the range that was stated.
By their numbers in this assay, from the lowest: compound 2; then compound 4; then compound 3; then compound 1.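

In this assay, hydrogen in place of methyl on this aromatic carbon, next to the ring nitrogen, gives a 4.6-fold higher number from compound 2 to compound 4 (0.66 log units; beyond the scatter) and so marks the position as sensitive to this change, beyond the scatter. For the compounds shown here, the earlier compounds offered only a halogen step elsewhere, so this is the first single-place reading at this carbon. No measurement on hand gives a reason for the step.

The compounds shown leave open how an ethyl or aminomethyl group at this carbon would read. Whether methyl is the best group here therefore stays undecided.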